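This account rests on a few compounds, and the source may have more. Where it says the series, first, only, none or still open, it means among the compounds named here.

The compounds measured so far:

Compound 1, `Cc1ccc(NC(=O)c2c(O)c3cccnc3n(-c3ccccc3)c2=O)cc1`, gives -3.5% in a functional assay on the whole organism for inhibition, with Rattus norvegicus as the target, read by paw edema, at a dose of 100 mg/kg by the oral route; a lower number here means less inhibition, a higher number more inhibition at the dose given (going by the name of the read-out).
Compound 2, `O=C(Nc1ccc([N+](=O)[O-])cc1)c1c(O)c2cccnc2n(-c2ccccc2)c1=O`, gives -7.6% in this assay.

Within the data shown here, both numbers sit close to zero, and the only step between them, a number 4.1 percentage points lower from compound 1 to compound 2 (within the scatter), is within the scatter, so neither compound can be told apart from the other in this assay. Compound 3, `O=C(Nc1cccc([N+](=O)[O-])c1)c1c(O)c2cccnc2n(-c2ccccc2)c1=O`, has not yet been measured. It differs from compound 2 by 3-nitrophenyl in place of 4-nitrophenyl on an amide-type nitrogen. Among the measured compounds shown here, no measured step bears directly on this change: the step from compound 1 to compound 2 swaps one group for another at the same place, whereas here the same atoms are merely joined differently. For the measured compounds named here, with no measured step to draw on and both measured numbers near zero, a step of no size beyond the scatter is expected, a number 2.6 percentage points higher from compound 2 to compound 3 (within the scatter). Compound 3 is therefore estimated to give -5% in this assay, between -20% and 12%.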

Compound 3, a percentage reported as inhibition, in the whole organism at one dose (the size of the read-out at that dose, not a potency): 5.7%
The estimate for compound 3 lay 10.7 percentage points below the measured number; measured number inside the range.
By their numbers in this assay, from the lowest: compounds 2, 1 and 3 (each within the scatter of the next, the first and the last beyond it).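

Joining the nitro group differently on the phenyl ring at the amide-type nitrogen does register in this assay: 3-nitrophenyl in place of 4-nitrophenyl gives a number 13.3 percentage points higher from compound 2 to compound 3 (beyond the scatter), a modest step and the first one here to clear the scatter. Set against 4-methylphenyl at the same place, 3-nitrophenyl gives a number 9.2 percentage points higher from compound 1 to compound 3 (within the scatter), so the separation holds only between the two nitrophenyl compounds. Nothing available explains the step between them.

On these data alone, it remains open whether the same change in attachment would matter for another group, such as 3-methylphenyl in place of 4-methylphenyl. As far as these compounds go, it is also open whether an amine or a carboxylic acid on this phenyl ring would give a larger number in this assay than these three compounds do.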